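A chloro added to compound 2

The source may report more compounds than this note shows. Statements on the series, on what has been measured and on what is new or still open speak of the compounds shown alone.

In a functional assay on MC-38 cells (Mus musculus) for antiproliferative activity, read by colorimetric assay and MTT assay (a higher number here means a weaker inhibitor, a lower number a stronger inhibitor), compound 1 `COc1ccc(S(=O)(=O)Nc2ccc(Cl)c3cc[nH]c23)cc1` gives 0.65 ug/mL and compound 2 `O=[N+]([O-])c1ccc(S(=O)(=O)Nc2cccc3cc[nH]c23)cc1` gives 7.2 ug/mL as the higher of the two numbers. Compound 2 is therefore the weaker inhibitor of this pair, and the gap lies beyond the scatter. The two compounds differ in more than one place, so the gap cannot be assigned to any single change.

For the measured compounds named here, compound 3 `O=[N+]([O-])c1ccc(S(=O)(=O)Nc2ccc(Cl)c3cc[nH]c23)cc1` has no measurement yet. It is compound 2 with chloro in place of hydrogen on an aromatic carbon para to a large group. Compound 1 carries the same chloro and stands at 0.65 ug/mL on the lower side of the pair, which points to a step toward a lower number, beyond the scatter. Compound 3 keeps the other substituent of compound 2, however, so only part of the gap is expected to appear. The expected change is a 4.5-fold lower number from compound 2 to compound 3 (0.65 log units; beyond the scatter) and it would mean stronger inhibition. In this assay compound 3 is estimated at 1.6 ug/mL with an expected range from 0.45 ug/mL to 5.5 ug/mL around that figure.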

Compound 3, half-maximal inhibitory concentration: 0.67 ug/mL
The estimate for compound 3 lay 2.4-fold (0.38 log units) above the measured number; the measured number falls inside the stated range.
By their numbers in this assay, from the lowest: compounds 1 and 3 (each within the scatter of the next); then compound 2.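

In this assay, for the compounds shown here, the single change of chloro in place of hydrogen on an aromatic carbon, para to a large group, is enough on its own to give a large step with the nitro kept in place (an 11-fold lower number from compound 2 to compound 3 (1.03 log units; beyond the scatter)). Going by these compounds alone, this is the first step that isolates this position, and it shows that potency in this pair turns on this one atom. With the chloro present, nitro in place of methoxy on an aromatic carbon leaves the result within the scatter (a 1.0-fold higher number from compound 1 to compound 3 (0.01 log units; within the scatter)), so in this setting the two groups cannot be told apart, and nothing measured here explains either step.

The compounds shown leave open whether the chloro gives a step of this size when methoxy stands in place of the nitro, and whether nitro and methoxy remain alike without the chloro. They also leave open whether another group on this carbon, such as bromo, methyl or an amine, would match the chloro.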